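This account rests on a few compounds, and the source may have more. Where it says the series, first, only, none or still open, it means among the compounds named here.

Compound 1, `CC(=O)Nc1c(C(O)(C(F)(F)F)C(F)(F)F)ccc2ccccc12`, gives 18 nM in an assay on LtK cells with ATP-sensitive inward rectifier potassium channel 11 (Homo sapiens) as the target; on this read-out higher numbers stand for an effect only at larger amounts of compound and lower numbers for an effect already at smaller amounts.
Compound 2, `O=C(Nc1c(C(O)(C(F)(F)F)C(F)(F)F)ccc2ccccc12)c1ccccc1`, gives 44 nM in this assay.
Compound 3, `O=C(Nc1c(C(O)(C(F)(F)F)C(F)(F)F)ccc2ccccc12)c1ccc(Br)cc1`, gives 47 nM in this assay.

Compound 4, `CC(=O)Nc1c(C(O)(C(F)(F)F)C(F)(F)F)cc(Br)c2ccccc12`, has not yet been measured. It differs from compound 1 in one place: bromo in place of hydrogen on an aromatic carbon. The same kind of change was made from compound 2 to compound 3, (bromo in place of hydrogen on an aromatic carbon), and there it gave a 1.1-fold higher number from compound 2 to compound 3 (0.03 log units; within the scatter). The two cores are not the same, the difference being (methyl in place of phenyl on a carbonyl carbon). The surroundings of the change also differ: in compound 4 the bromo sits on a ring that is part of a fused or bridged system of two rings, ortho to a fused ring, meta to a fused ring, meta to a large group and para to an acetamido group, whereas in compound 3 it sits para to a large group. Beside a 1.1-fold higher number from compound 2 to compound 3 (0.03 log units; within the scatter), the step from compound 1 to compound 4 is expected to be a 1.4-fold higher number from compound 1 to compound 4 (0.14 log units; within the scatter), an expectation resting on that single earlier step on a different core. Compound 4 is therefore estimated at 25 nM, likely between 8 nM and 80 nM.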

Compound 4, half-maximal effective concentration: 5310 nM
For compound 4 the middle estimate is 210-fold (2.33 log units) below the measured one; the measured number lies above the stated range.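

The bromo change gave a 300-fold higher number from compound 1 to compound 4 (2.47 log units; beyond the scatter) in this assay and so did not carry over from one core to the other. The two steps stand far apart: the same change on two cores in this assay, a 1.1-fold higher number (0.03 log units; within the scatter) from compound 2 to compound 3 and a 300-fold higher number (2.47 log units; beyond the scatter) from compound 1 to compound 4, 280-fold (2.44 log units) apart, beyond the scatter of two such steps

This rests on one pair of steps in which the core and the place of the bromo differ together, so it does not show which of the two accounts for the gap, nor how the change would behave on any further core.

The compounds shown leave open what a chloro, a methyl or an amine in place of the same hydrogen of compound 1 would give. They also leave open what a bromo on the fused ring system of compound 2 would give.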